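The source may report more compounds than this note shows. Statements on the series, on what has been measured and on what is new or still open speak of the compounds shown alone.

Notes on the series: compound 1 `Cc1cn([C@@H]2O[C@H](CO[Si](C)(C)C(C)(C)C)[C@@]3(OS(=O)(=O)C=C3NCC(=O)OCc3ccccc3)[C@H]2O[Si](C)(C)C(C)(C)C)c(=O)n(C)c1=O` and compound 2 `Cc1cn([C@@H]2O[C@H](CO[Si](C)(C)C(C)(C)C)[C@@]3(OS(=O)(=O)C=C3NCCC(=O)OCc3ccccc3)[C@H]2O[Si](C)(C)C(C)(C)C)c(=O)n(C)c1=O` share the core of compound 1 and differ only in the chain on the amine nitrogen. In a functional assay on CCRF-CEM cells (Homo sapiens) (on this read-out lower numbers stand for higher toxicity in this test and higher numbers for lower toxicity in this test), compound 1 gives 250000 nM. Compound 2 gives > 250000 nM, which is a limit of the assay, so compound 2 has no exact number.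

Compound 3 `Cc1cn([C@@H]2O[C@H](CO[Si](C)(C)C(C)(C)C)[C@@]3(OS(=O)(=O)C=C3NCC(=O)C(N)=O)[C@H]2O[Si](C)(C)C(C)(C)C)c(=O)n(C)c1=O` carries carbamoylcarbonyl in place of (benzyloxycarbonyl)methyl on a saturated chain carbon bound to an amine nitrogen.

Going by the values given here, only one measured step bears on this change: a number no lower from compound 1 to compound 2 (the limit leaves the size open). Its size cannot be read, and the relevant constraint is the limit of > 250000 nM in this assay, at which 1 of the 2 values shown sits. That step also keeps the benzyl ester, so it is only a loose guide to a change that removes the aromatic ring.

The expectation therefore rests on compound 1 at 250000 nM, which points to low toxicity in this assay for this chain position. Any measurable shift would be expected toward a lower number, but no step beyond the scatter is expected: an at least 1.2-fold lower number from compound 2 to compound 3 (0.09 log units; that floor lies within the scatter). For compound 3 the estimated value is 200000 nM, with an expected range of 80000 nM to 250000 nM.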

Compound 3, half-maximal cytotoxic concentration: 9960 nM
For compound 3 the middle estimate is 20-fold (1.30 log units) above the measured one; the whole stated range lies above it.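

The chain on the amine nitrogen is not neutral for toxicity in this assay: the two benzyl esters stay at the top of the range, while the first non-benzyl chain gives a clear drop, a 25-fold lower number from compound 1 to compound 3 (1.40 log units; beyond the scatter), with carbamoyl in place of benzyloxy on a carbonyl carbon. Carbamoylcarbonyl in place of (benzyloxycarbonyl)methyl on a saturated chain carbon bound to an amine nitrogen gives an at least 25-fold lower number from compound 2 to compound 3 (1.39 log units; beyond the scatter), so the same position that looked flat across the benzyl esters responds strongly once the six-membered aromatic ring leaves and a hydrogen-bond donor enters. Compound 2 stands at a limit of the assay and not at a number, so that step gives only a floor for the size: the limit of > 250000 nM in this assay, at which 1 of the 3 values shown sits.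

The change removes the aromatic ring and adds the carbamoyl group in one move, and the compounds shown do not separate the share of each. A carboxylic acid or a simple methyl ester on the same chain, or a benzyl amide, would show whether the drop follows the loss of the benzyl group or the arrival of the primary amide.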